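This account rests on a few compounds, and the source may have more. Where it says the series, first, only, none or still open, it means among the compounds named here.

Compound 1 `COc1ccc(C2=NN(C3=NC(=O)/C(=C4\C(=O)Nc5ccc(Br)cc54)S3)C(c3ccc(OC)cc3)C2)cc1` and compound 2 `COc1ccc(C2=NN(C3=NC(=O)/C(=C4\C(=O)Nc5ccc(Cl)cc54)S3)C(c3ccc(OC)cc3)C2)cc1` are built on one shared core, while compound 3 `COc1ccc(-c2cc(-c3ccc(Cl)cc3)n(C3C(=O)Nc4ccc(Br)cc43)n2)cc1` rests on a different one. Compound 2 differs from compound 1 only by chloro in place of bromo on an aromatic carbon. In a functional assay on cells (Cancer cell lines, Homo sapiens) for cytotoxicity, read by sulforhodamine B assay, with a stated time of 48 h (a lower number here means a stronger inhibitor of growth, a higher number a weaker inhibitor of growth), compound 1 gives 200 nM and compound 2 gives 200 nM, so that no change at the digits printed from compound 1 to compound 2 (within the scatter). In this assay compound 3 gives 5480 nM, a much weaker inhibitor of growth than either of the other two; the difference between its core and the core of compound 1 is not broken down here. For the measured compounds named here, compound 4 `COc1ccc(-c2cc(-c3ccc(Cl)cc3)n(C3C(=O)Nc4ccc(Cl)cc43)n2)cc1` has not yet been tested; it differs from compound 3 by chloro in place of bromo on an aromatic carbon, the same change, at a place described in the same words, as the one that turns compound 1 into compound 2. Because no change at the digits printed from compound 1 to compound 2 (within the scatter), the step is expected to be small here too, estimated at a 1.0-fold higher number from compound 3 to compound 4 (0.00 log units; within the scatter). Compound 4 is therefore expected to give about 5500 nM in this assay, within an estimated range from 2500 nM to 12000 nM.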

Compound 4, concentration for 50% growth inhibition: 3940 nM
The estimate for compound 4 lay 1.4-fold (0.14 log units) above the measured number; the range from low to high includes it.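

In this assay, placing chloro where bromo stood gives a 1.4-fold lower number from compound 3 to compound 4 (0.14 log units; within the scatter), so this swap again leaves the number essentially unmoved, now on a second core. Set side by side, the two steps do not differ: the same change on two cores in this assay, no change at the digits printed (within the scatter) from compound 1 to compound 2 and a 1.4-fold lower number (0.14 log units; within the scatter) from compound 3 to compound 4, 1.4-fold (0.14 log units) apart, within the scatter of two such steps

This shows that, for this one swap, what was seen on the core of compound 1 also held on the core of compound 3, so the earlier step was a fair guide here. It does not show that other changes would carry from one core to the other in the same way, and two pairs of compounds cannot establish a rule for the whole series or explain why the swap changes so little.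

The compounds shown leave open what a quite different group on that aromatic carbon, such as an amine, a carboxylic acid or a longer chain, would do on either core. They also leave open whether any such group would give steps that match between the two cores, as the chloro and bromo pairs do.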